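Aryl ring substituent swap on the shared core

The compounds below may be only part of what the source reports. "The series", "measured", "known", "first", "only" and "open" are said of these compounds alone.

Among the three compounds measured so far in a functional assay on A549 cells (Homo sapiens) for inhibition, read by MTT assay, with a stated time of 72 h (on this read-out lower numbers stand for stronger inhibition and higher numbers for weaker inhibition), compound 3 `COc1cc2c(Oc3ccc(NC(=O)c4nn(-c5ccccc5OC(F)(F)F)c(=O)cc4C)cc3F)ccnc2cc1OCCCN1CCCC1` stands lowest, giving 140 nM. Compound 1 `COc1cc2c(Oc3ccc(NC(=O)c4nn(-c5ccccc5)c(=O)cc4C)cc3F)ccnc2cc1OCCCN1CCCC1` gives 370 nM and compound 2 `COc1cc2c(Oc3ccc(NC(=O)c4nn(-c5ccccc5C)c(=O)cc4C)cc3F)ccnc2cc1OCCCN1CCCC1` gives 1300 nM. The measured steps are a 2.6-fold lower number from compound 1 to compound 3 (0.42 log units; beyond the scatter), a 3.5-fold higher number from compound 1 to compound 2 (0.55 log units; beyond the scatter) and a 9.3-fold lower number from compound 2 to compound 3 (0.97 log units; beyond the scatter).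

Compound 4 `COc1ccc(-n2nc(C(=O)Nc3ccc(Oc4ccnc5cc(OCCCN6CCCC6)c(OC)cc45)c(F)c3)c(C)cc2=O)cc1` differs from compound 3 by 4-methoxyphenyl in place of 2-(trifluoromethoxy)phenyl on an aromatic nitrogen. For the measured compounds named here, no measured step touches a 4-methoxyphenyl; every measured step concerns the group that compound 3 carries as trifluoromethoxy. Those steps show that a change on this ring moves this assay by modest amounts in either direction: a 2.6-fold lower number from compound 1 to compound 3 (0.42 log units; beyond the scatter) lowered the number, whereas a 3.5-fold higher number from compound 1 to compound 2 (0.55 log units; beyond the scatter) raised it. Loss of the trifluoromethoxy alone would point back toward compound 1, and the incoming methoxy has no precedent in the series. A modest rise from compound 3 is therefore expected, estimated as a 2.9-fold higher number from compound 3 to compound 4 (0.46 log units; beyond the scatter). For compound 4 the expected value in this assay is 400 nM, with a range of 120 nM to 1500 nM.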

Compound 4, half-maximal inhibitory concentration: 2770 nM
The estimate for compound 4 lay 6.9-fold (0.84 log units) below the measured number; measured number outside the range, above it.
By their numbers in this assay, from the lowest: compound 3; then compound 1; then compound 2; then compound 4.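

For the compounds shown here, the change from 2-(trifluoromethoxy)phenyl to 4-methoxyphenyl gives a 20-fold higher number from compound 3 to compound 4 (1.30 log units; beyond the scatter) in this assay, the largest step at this position so far, so this ring substituent can shift the number much further than the earlier compounds showed. The methoxy also gives a 7.5-fold higher number from compound 1 to compound 4 (0.87 log units; beyond the scatter) against the plain phenyl and the change from 2-methylphenyl gives a 2.1-fold higher number from compound 2 to compound 4 (0.33 log units; beyond the scatter), leaving 4-methoxyphenyl with the highest number of the four, while compound 3 alone lies below compound 1 and goes against any rule that substitution on this ring raises the number. No measurement shown bears on the reason for these steps.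

Compound 4 differs from compound 3 in both the group and its place on the ring, and these two changes cannot be separated here. As far as these compounds go, how an amine or a carboxylic acid on this ring would read remains open.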